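The source may report more compounds than this note shows. Statements on the series, on what has been measured and on what is new or still open speak of the compounds shown alone.

Compound 3 `O=c1c2ccccc2[se]n1-c1nnc(-c2ccccc2Cl)s1` gives 40200 nM in a functional assay on SSMC-7721 cells (Homo sapiens) for antiproliferative activity, read by CCK-8 assay, with a stated time of 48 h; a higher number here means a weaker inhibitor, a lower number a stronger inhibitor. Its number sits between those of compound 2 `O=c1c2ccccc2[se]n1-c1nnc(-c2ccc(Cl)cc2)s1`, which gives 24400 nM, and compound 1 `O=c1c2ccccc2[se]n1-c1nnc(-c2ccc(Br)cc2)s1`, which gives 68200 nM; both gaps, a 1.6-fold higher number from compound 2 to compound 3 (0.22 log units; within the scatter) and a 1.7-fold lower number from compound 1 to compound 3 (0.23 log units; within the scatter), fall inside the scatter. Going by the values given here, the only step beyond the scatter in the set is a 2.8-fold lower number from compound 1 to compound 2 (0.45 log units; beyond the scatter), a modest one for a halogen swap.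

Compound 4 `O=c1c2ccccc2[se]n1-c1nnc(-c2ccccc2[N+](=O)[O-])s1` arises from compound 3 by nitro in place of chloro on an aromatic carbon. Among the compounds with values here, no measured step exchanges a halogen for a nitro group, so the bearing of the series is indirect; the halogen steps seen were small. The expected step is therefore a 1.0-fold lower number from compound 3 to compound 4 (0.00 log units; within the scatter) in this assay, not beyond the scatter in either direction. Compound 4 is estimated at 40000 nM, with a range of 14000 nM to 110000 nM.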

Compound 4, half-maximal inhibitory concentration: 22500 nM
For compound 4 the middle estimate is 1.8-fold (0.25 log units) above the measured one; measured number inside the range.
By their numbers in this assay, from the lowest: compounds 4, 2, 3 and 1 (each within the scatter of the next, the first and the last beyond it).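

In this assay, nitro in place of chloro on an aromatic carbon, ortho to a large group, gives a 1.8-fold lower number from compound 3 to compound 4 (0.25 log units; within the scatter) and so stays within the scatter. At this position, then, three heavy atoms and two hydrogen-bond acceptors can replace a single chlorine without a step beyond the scatter, and a non-halogen group reads like the halogen there. No data shown bear on the cause of this.

From the compounds shown here alone, an amine or a carboxylic acid at this position remains open. So does nitro in the place held by the chloro of compound 2.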